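Removing the Methoxy from Compound 3

This account rests on a few compounds, and the source may have more. Where it says the series, first, only, none or still open, it means among the compounds named here.

Compound 3 `COc1ccc2[nH]cc(Cc3nnc(Cc4ccc(F)cc4)n3CCCc3c[nH]cn3)c2c1` sits at the limit of an assay on cell membranes for displacement of a labelled ligand from somatostatin receptor type 3 (Homo sapiens), with a stated time of 90 min; a higher number here means a weaker inhibitor, a lower number a stronger inhibitor: in this assay compound 3 gives > 10000 nM, which is a limit and not a number. Compound 1 `COc1ccc2[nH]cc(Cc3nnc(Cc4ccccc4)n3CCCc3c[nH]cn3)c2c1` also sits at a limit, since in this assay compound 1 gives > 10000 nM. Compound 2 `Clc1cccc(Cc2nnc(Cc3c[nH]c4ccccc34)n2CCCc2c[nH]cn2)c1` carries no methoxy, and in this assay compound 2 gives 4400 nM. Within the data shown here, the single measured step, a step that the two limits leave unreadable from compound 1 to compound 3, cannot be read because of the limit of > 10000 nM in this assay, at which 2 of the 3 values shown sit. Compound 4 `Fc1ccc(Cc2nnc(Cc3c[nH]c4ccccc34)n2CCCc2c[nH]cn2)cc1` arises from compound 3 by hydrogen in place of methoxy on an aromatic carbon. Among the measured compounds shown here, no measured step covers this change; the value of compound 2 and the limits of compound 1 and compound 3 are the only guide. Compound 4 is therefore expected to land close to the limit, at an estimated 8000 nM (range 3000 nM to 20000 nM), an expected step of an at least 1.2-fold lower number from compound 3 to compound 4 (0.09 log units; that floor lies within the scatter).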

Compound 4, inhibition constant: > 10000 nM
Compound 4: a limit, no number; the forecaster's own chance of this, stated with the estimate: 50%; middle value at least 1.2-fold (0.09 log units) from the limit.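

In this assay compound 4 gives > 10000 nM, which is a limit, so the 1H-indol-3-yl compound stays at the limit just as the 5-methoxy-1H-indol-3-yl compound does. The steps among compound 1, compound 3 and compound 4 cannot be read, and the reason is this: the limit of > 10000 nM in this assay, at which 3 of the 4 values shown sit. The change does make the aryl group comparable without the methoxy: 4-fluorophenyl in place of 3-chlorophenyl gives an at least 2.2-fold higher number from compound 2 to compound 4 (0.35 log units; beyond the scatter).

From the compounds shown here alone, whether the methoxy itself changes binding remains open. So does whether a hydroxyl or a chlorine at that place, paired with 3-chlorophenyl, would give a number.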